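Opening the Pyrrolidine Ring to a Primary Amine

The source may hold more compounds than are shown below. What is called first, only, known or untested is meant among the compounds shown, and "the series" means these compounds.

Measured compounds:
compound 1, `CNCCCc1c[nH]c2ccc(F)cc12`, 26 nM
compound 2, `Fc1ccc2[nH]cc(CCCN3CCCC3)c2c1`, 210 nM

Both compounds share the same core and differ only in the amine at the end of the chain. For the measured compounds named here, in an assay on isolated protein for inhibition of Myeloperoxidase (Homo sapiens) (a higher number here means a weaker inhibitor, a lower number a stronger inhibitor), compound 2 gives 210 nM, the higher of the two numbers, with compound 1 as its only neighbour at 26 nM. Going by the values given here, the single measured step, an 8.1-fold higher number from compound 1 to compound 2 (0.91 log units; beyond the scatter), shows that replacing methylamino with pyrrolidin-1-yl weakened inhibition.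

Compound 3, `NCCCCc1c[nH]c2ccc(F)cc12`, moves in the opposite direction: aminomethyl in place of pyrrolidin-1-yl on a saturated chain carbon, three bonds along the chain from an aromatic carbon. The ring amine is traded for a smaller, open primary amine, a change resembling the reverse of the measured step, because an 8.1-fold higher number from compound 1 to compound 2 (0.91 log units; beyond the scatter) accompanied the introduction of the ring. The expected step, a 6.0-fold lower number from compound 2 to compound 3 (0.78 log units; beyond the scatter), is therefore towards stronger inhibition. Compound 3 is estimated at 35 nM, within a range of 10 nM to 120 nM.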

Compound 3, half-maximal inhibitory concentration: 12 nM
Beside the measured number, compound 3's estimate is 2.9-fold (0.46 log units) above it, and the stated range covers the measured number.
By their numbers in this assay, from the lowest: compound 3; then compound 1; then compound 2.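

In this assay, putting aminomethyl in place of pyrrolidin-1-yl gives a large gain (an 18-fold lower number from compound 2 to compound 3 (1.24 log units; beyond the scatter)), and this does more than cancel the loss seen with the ring. Aminomethyl also improves on methylamino at this place (a 2.2-fold lower number from compound 1 to compound 3 (0.34 log units; beyond the scatter)), which makes compound 3 the strongest inhibitor of the three and shows that even a modest change to the amine at the end of the chain shifts the number beyond the scatter. Nothing measured here bears on why the amines fall in this order.

Going by these compounds, it remains open whether dimethylamino, ethylamino or a longer chain ending in a primary amine would fit this order. On these data alone, it is also open what a hydroxyl group or an amide at the end of the chain would do.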